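Swapping 4-cyanophenyl for 2,4-difluorophenyl

This account rests on a few compounds, and the source may have more. Where it says the series, first, only, none or still open, it means among the compounds named here.

Measured so far in a functional assay on MIA PaCa-2 cells (Homo sapiens) for cytotoxicity, read by MTT assay, with a stated time of 4 h; on this read-out lower numbers stand for stronger inhibition and higher numbers for weaker inhibition:
- compound 1 `COC1=CC(=O)c2c(COc3ccc(N)cc3)c(C)n(C)c2C1=O`: 504 nM
- compound 2 `COC1=CC(=O)c2c(COc3ccc([N+](=O)[O-])cc3F)c(C)n(C)c2C1=O`: 529 nM
- compound 3 `COC1=CC(=O)c2c(COc3ccc(C#N)cc3)c(C)n(C)c2C1=O`: 463 nM

Compound 3, at 463 nM, cannot be separated from the other two, since its value lies within the usual scatter of both compound 1 and compound 2. The next molecule, compound 4 `COC1=CC(=O)c2c(COc3ccc(F)cc3F)c(C)n(C)c2C1=O`, keeps the shared core but carries 2,4-difluorophenyl in place of 4-cyanophenyl on an oxygen on a saturated carbon.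

Going by the values given here, only one measured step bears directly on this part of the molecule: a 1.1-fold lower number from compound 1 to compound 3 (0.04 log units; within the scatter). That swap of amino for cyano on an aromatic carbon stayed within the scatter. Compound 2, which also carries fluorine on its aromatic ring, gives 529 nM, again level with the others. Among the compounds with values here, no measured compound carries this exact pair of fluorines, so the evidence is thin. Even so, no step beyond the scatter is expected in this assay, in either direction.

The expected step is a 1.1-fold higher number from compound 3 to compound 4 (0.03 log units; within the scatter). For compound 4, the estimated value is 500 nM, with an expected range from 270 nM to 930 nM.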

Compound 4, half-maximal inhibitory concentration: 255 nM
The estimate for compound 4 lay 2.0-fold (0.29 log units) above the measured number; measured number below the stated range.
By their numbers in this assay, from the lowest: compounds 4, 3, 1 and 2 (each within the scatter of the next, the first and the last beyond it).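

In this assay, the group on the oxygen now gives a step beyond the scatter, the only one among these compounds: fluoro in place of nitro on an aromatic carbon gives a 2.1-fold lower number from compound 2 to compound 4 (0.32 log units; beyond the scatter), a modest change. The other two steps, a 1.8-fold lower number from compound 3 to compound 4 (0.26 log units; within the scatter) and a 2.0-fold lower number from compound 1 to compound 4 (0.30 log units; within the scatter), stay within the scatter, so 2,4-difluorophenyl cannot be told apart from 4-cyanophenyl or 4-aminophenyl here, and the one clear difference rests on a single pair of compounds. Nothing available gives a reason for that difference.

As far as these compounds go, it remains open whether a ring carrying only one fluorine would behave like compound 4. The compounds shown also leave open how a chloro group, a methoxy group or a carboxylic acid on the ring would read in this assay.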